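This account rests on a few compounds, and the source may have more. Where it says the series, first, only, none or still open, it means among the compounds named here.

Of the compounds shown here, three that share one core have been tested in a functional assay on T47D cells (Homo sapiens) for antiproliferative activity, read by MTT assay, with a stated time of 72 h; on this read-out lower numbers stand for stronger inhibition and higher numbers for weaker inhibition. Compound 1 `CCCn1ccnc1-c1cc(OC)c(OC)c(OC)c1` carries a propyl group on a ring nitrogen of that core. In this assay compound 1 gives only a limit of the assay, > 100000 nM, so no number is known for it. Compound 2 `COc1cc(-c2nccn2S(=O)(=O)c2ccc(C)cc2)cc(OC)c1OC` likewise gives only a limit in this assay, > 100000 nM. Going by the values given here, compound 3 `COc1cc(-c2nccn2-c2cccc([N+](=O)[O-])c2)cc(OC)c1OC` is the one compound that yields a number, 17900 nM in this assay. Where compound 1 stands is therefore told by a limit alone: the limit of > 100000 nM in this assay, at which 2 of the 3 values shown sit.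

Compound 4 `COc1cc(-c2nccn2-c2ccc(Br)cc2)cc(OC)c1OC` has not yet been measured in this assay. It differs from compound 1 in a single place, (4-bromophenyl in place of propyl on an aromatic nitrogen). Among the compounds with values here, the only guidance comes from compound 3, which also bears an aromatic ring on that nitrogen and gives a number, 17900 nM. The propyl group of compound 1, by contrast, gives only a limit. On that basis the move an at least 10-fold lower number from compound 1 to compound 4 (1.00 log units; beyond the scatter) is expected to bring the value from the limit into the measurable range, a step toward stronger inhibition well beyond the scatter. Compound 4 is expected to give about 10000 nM in this assay, somewhere between 2000 nM and 60000 nM.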

Compound 4, half-maximal inhibitory concentration: 24600 nM
Compound 4: middle estimate off by 2.5-fold (0.39 log units), on the low side; the measured number falls inside the stated range.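

Replacing propyl with 4-bromophenyl on this aromatic nitrogen brings the value in this assay off the limit and into the measurable range, giving an at least 4.0-fold lower number from compound 1 to compound 4 (0.60 log units; beyond the scatter). That step is a minimum and not an exact size, because its starting point, compound 1, is only a limit of the assay: the limit of > 100000 nM in this assay, at which 2 of the 4 values shown sit.

Compound 3 gives 17900 nM and compound 4 gives 24600 nM, so a number in this assay now appears with two differently substituted aromatic rings on this nitrogen, which means it does not depend on one particular ring substituent.

The compounds shown leave open how much of the step comes from the six-membered aromatic ring itself and how much from its bromine, a question that a plain phenyl group on the same nitrogen could help to settle. They also leave open whether a ring is needed at all, or whether a longer chain, such as hexyl, or a benzyl group, with its ring held one carbon away from the nitrogen, would also give a measurable value.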